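A few compounds are considered here, and "the series" means these few. Any claim that something is new, unique, unknown or untested is made for them only; others in the source may bear on it.

Of the compounds shown here, two have so far been measured in a functional assay on cells (Homo sapiens) for cytotoxicity, read by MTT assay, with a stated time of 24 h; on this read-out higher numbers stand for weaker inhibition and lower numbers for stronger inhibition. Compound 1 `CCCCCCCCCCCCCCNC(=O)[C@H](CO)/N=C/c1cccc([N+](=O)[O-])c1` gives 104000 nM in this assay, the highest of the two numbers, so it is the weaker of the pair. Compound 2 `CCCCCCCCCCCCCCNC(=O)[C@H](CO)NCc1ccccc1[N+](=O)[O-]` gives 29400 nM in this assay, a lower number whose gap from compound 1 lies beyond the usual scatter, so compound 2 inhibits more strongly than compound 1. Compound 3 `CCCCCCCCCCCCCCNC(=O)[C@H](CO)/N=C/c1cccc(O)c1` has not yet been measured. It differs from compound 1 in a single place: hydroxy in place of nitro on an aromatic carbon. For the measured compounds named here, no measured pair shows what this change does, so the data give no direction for it. The step of a 1.2-fold lower number from compound 1 to compound 3 (0.06 log units; within the scatter) is expected to be small, within the scatter. Compound 3 is accordingly expected to give about 90000 nM in this assay, with a plausible range from 30000 nM to 300000 nM.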

Compound 3, half-maximal inhibitory concentration: 32600 nM
Compound 3: middle estimate off by 2.8-fold (0.44 log units), on the high side; the measured number falls inside the stated range.
By their numbers in this assay, from the lowest: compounds 2 and 3 (each within the scatter of the next); then compound 1.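

Going from 3-nitrophenyl to 3-hydroxyphenyl in this assay gives a step (a 3.2-fold lower number from compound 1 to compound 3 (0.50 log units; beyond the scatter)) that is modest in size but beyond the scatter, and it points towards stronger inhibition. For the compounds shown here, this is the first sign that the group at this place on the aromatic ring matters for this read-out: the number moves when nitro, with its three heavy atoms and no hydrogen-bond donor, gives way to hydroxy, with one heavy atom and one donor. Nothing measured here accounts for the shift.

As far as these compounds go, whether an amine or a methoxy group at the same place would move the number further remains open. So does whether hydroxy would give a similar step with a shorter chain on the amide.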